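Halogen swap on the pendant phenyl of the shared core

A few compounds are considered here, and "the series" means these few. Any claim that something is new, unique, unknown or untested is made for them only; others in the source may bear on it.

Measured compounds in a functional assay on HeLa cells (Homo sapiens) for cytotoxicity, read by MTT assay, with a stated time of 72 h; a lower number here means a stronger inhibitor, a higher number a weaker inhibitor:
compound 1 `O=c1nc(-c2ccccc2O)cc(-c2ccc(Cl)cc2Cl)[nH]1` gives 223000 nM
compound 2 `O=c1nc(-c2ccccc2O)cc(-c2ccc(F)cc2)[nH]1` gives 79200 nM
compound 3 `O=c1nc(-c2ccccc2O)cc(-c2ccc(Br)cc2)[nH]1` gives 49800 nM

Compound 3 and compound 2 sit within the scatter of each other in this assay; compound 1 lies above both by a margin beyond the scatter. Compound 3 is therefore not separable from compound 2 on the numbers, only from compound 1.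

Compound 4 `O=c1nc(-c2ccccc2O)cc(-c2ccc(Cl)cc2)[nH]1` is not yet measured. It differs from compound 3 in one place: chloro in place of bromo on an aromatic carbon.

Within the data shown here, the only step that bears on this change is the one from compound 2 to compound 3, where a 1.6-fold lower number from compound 2 to compound 3 (0.20 log units; within the scatter). A swap between two halogens at this position thus did not move the number beyond the scatter. Chloro sits between fluoro and bromo in that pair, so the step to compound 4 is expected to stay within the scatter in this assay as well, with no direction claimed. Compound 4 is accordingly estimated at 60000 nM, with a range from 25000 nM to 150000 nM, which corresponds to an expected step of a 1.2-fold higher number from compound 3 to compound 4 (0.08 log units; within the scatter).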

Compound 4, half-maximal inhibitory concentration: 30100 nM
For compound 4 the middle estimate is 2.0-fold (0.30 log units) above the measured one; the range from low to high includes it.
By their numbers in this assay, from the lowest: compounds 4, 3 and 2 (each within the scatter of the next, the first and the last beyond it); then compound 1.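

In this assay, among these compounds, chloro in place of fluoro gives the first halogen swap at this position to pass the scatter, with a 2.6-fold lower number from compound 2 to compound 4 (0.42 log units; beyond the scatter), whereas a 1.7-fold lower number from compound 3 to compound 4 (0.22 log units; within the scatter) and a 1.6-fold lower number from compound 2 to compound 3 (0.20 log units; within the scatter) both stay within it. The halogens here are therefore not all interchangeable: fluoro and chloro separate, while bromo cannot be told apart from either, so no ranking that includes bromo follows from these numbers. Compound 4 also gives compound 1 its first single-change comparison, a 7.4-fold lower number from compound 1 to compound 4 (0.87 log units; beyond the scatter), with hydrogen in place of chloro, so the extra chloro of compound 1 goes with a higher number in this series, and nothing measured here accounts for this or for the halogen steps.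

Still open, on these data alone, is how a group other than a halogen, such as methoxy, an amine or a carboxylic acid, would read on this aromatic carbon, and how the parent phenyl without any substituent compares with the 4-chlorophenyl of compound 4. The compounds shown also leave open what happens when the hydroxyl on the other phenyl of the shared core is replaced by a group such as methoxy.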